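This account rests on a few compounds, and the source may have more. Where it says the series, first, only, none or still open, it means among the compounds named here.

Compound 2, with structure `CCc1c(OC)nc2nc(-c3n[nH]c(C)n3)cn2c1C`, is one of two compounds that have been examined so far, and in a functional assay on the whole organism with Rattus norvegicus as the target (on this read-out higher numbers stand for an effect only at larger amounts of compound and lower numbers for an effect already at smaller amounts), compound 2 gives > 50 mg/kg, which is a limit of the assay rather than a number. Its neighbour compound 1, with structure `CCc1c(OC)nc2nc(-c3nc(C)c(C)s3)cn2c1C`, is in the same position: in this assay compound 1 gives > 50 mg/kg, again a limit. For the measured compounds named here, the single step between them, a step that the two limits leave unreadable from compound 1 to compound 2, therefore cannot be read, and the only evidence is the limit of > 50 mg/kg in this assay, at which 2 of the 2 values shown sit. The next compound, compound 3 with structure `CCc1c(OC)nc2nc(-c3cnco3)cn2c1C`, differs from compound 2 in one place: 1,3-oxazol-5-yl in place of 5-methyl-1H-1,2,4-triazol-3-yl on an aromatic carbon. Going by the values given here, no measured step bears on this change with a readable size, because the step from compound 1 to compound 2 is hidden by two limits, so there is no basis for expecting a step in either direction beyond the scatter, and the most likely outcome is that compound 3 also sits at the limit. The step expected from compound 2 to compound 3 is accordingly a number no higher from compound 2 to compound 3 (the limit leaves the size open). Compound 3 is estimated at 50 mg/kg, within 10 mg/kg and 150 mg/kg.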

Compound 3, minimum effective dose: > 50 mg/kg
Compound 3: no number, only a limit (the forecaster's own chance of this, stated with the estimate: 70%); the middle value lies on the limit itself.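

In this assay compound 3 gives > 50 mg/kg as a limit and not a number. With compound 1 and compound 2 also at limits, no step among these three compounds can be read. The compounds shown leave open at what dose, if any, 4,5-dimethyl-1,3-thiazol-2-yl, 5-methyl-1H-1,2,4-triazol-3-yl or 1,3-oxazol-5-yl on the shared core would give an effect in this assay and how the three would rank.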